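The source may report more compounds than this note shows. Statements on the series, on what has been measured and on what is new or still open speak of the compounds shown alone.

Of the compounds shown here, three built on one shared core have been measured so far. Compound 1 `COc1ccc2nc(C(=O)Nc3ccc(-c4ccccc4)cc3)c(C)c(O)c2c1` gives 27.2% in a functional assay on A-375 cells (Homo sapiens) for antiproliferative activity, read by MTT assay, with a stated time of 24 h, tested at 3.7 ug/mL; on this read-out higher numbers stand for a stronger effect at the one concentration tested and lower numbers for a weaker effect. Compound 2 `Cc1c(C(=O)Nc2ccc(-c3ccccc3)cc2)nc2ccccc2c1O` gives 17.3% in this assay, and compound 3 `COc1ccc2nc(C(=O)Nc3ccc(-c4ccccc4)cc3)c(C)c(C(=O)O)c2c1` gives 33.7% in this assay. On these numbers compound 3 stands highest of the three, yet its gap to compound 1 lies within the scatter and only its gap to compound 2 lies beyond it, so compound 3 cannot be called the strongest of the set. Compound 4 `Cc1c(C(=O)Nc2ccc(-c3ccccc3)cc2)nc2ccccc2c1C(=O)O` has not yet been measured. It differs from compound 3 in one place: hydrogen in place of methoxy on an aromatic carbon. This same change has been seen once before in the set, as the step of a number 9.9 percentage points lower from compound 1 to compound 2 (within the scatter). That step was small, so for compound 4 only a small downward step in this assay is expected, one that need not pass beyond the scatter, with a number 8.7 percentage points lower from compound 3 to compound 4 (within the scatter) as the estimated step. Compound 4 is therefore estimated at 25%, within a range from 12% to 38%.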

Compound 4, a percentage reported as inhibition, at one concentration (the size of the read-out at that concentration, not a potency): 16.3%
Estimate against measurement, compound 4: 8.7 percentage points above, and the stated range covers the measured number.
By their numbers in this assay, from the lowest: compounds 4, 2, 1 and 3 (each within the scatter of the next, the first and the last beyond it).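

Hydrogen in place of methoxy gives a number 17.4 percentage points lower from compound 3 to compound 4 (beyond the scatter) on the core carrying the carboxy group, whereas the same change stayed within the scatter on the core carrying the hydroxy group. The two steps point the same way and their sizes cannot be told apart, so a single downward step shared by both cores fits the numbers: the same change on two cores in this assay, a number 9.9 percentage points lower (within the scatter) from compound 1 to compound 2 and a number 17.4 percentage points lower (beyond the scatter) from compound 3 to compound 4, 7.5 percentage points apart, within the scatter of two such steps. Carboxy in place of hydroxy, now also seen without the methoxy group, gives a number 1 percentage points lower from compound 2 to compound 4 (within the scatter) and so shows no clear effect on either core: the same change on two cores in this assay, a number 6.5 percentage points higher (within the scatter) from compound 1 to compound 3 and a number 1 percentage points lower (within the scatter) from compound 2 to compound 4, 7.5 percentage points apart, within the scatter of two such steps.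

The compounds shown carry only methoxy or hydrogen on this aromatic carbon, so it stays open how an ethoxy group, a fluorine atom or an amine would fare there. Each number comes from one concentration, so it tells only of a stronger or weaker effect at that concentration.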